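From an Amide to an Amine on the Shared Core

The source may report more compounds than this note shows. Statements on the series, on what has been measured and on what is new or still open speak of the compounds shown alone.

The study follows a single change on the shared core, read in an assay for inhibition of 15-hydroxyprostaglandin dehydrogenase [NAD(+)] (Homo sapiens), read by fluorescence, with a stated time of 15 min, in the presence of a further agent that is not named here; on this read-out higher numbers stand for weaker inhibition and lower numbers for stronger inhibition. Compound 1 `CCCC[S+]([O-])c1sc2nc(-c3nccs3)cc(-c3ccc(C(=O)N(C)C)cc3)c2c1N` gives 5.9 nM in this assay, the lowest of the two numbers reported. Compound 2 `CCCC[S+]([O-])c1cc2c(-c3ccccc3)nc(-c3ccccc3)nc2s1` gives 93 nM, a step up from compound 1 that lies beyond the usual scatter of this assay. Compound 3 `CCCCSc1sc2nc(-c3cccs3)cc(-c3ccccc3)c2c1N` reaches only a limit of this assay, reported as > 80 nM, and the record notes (the limit of > 80 nM in this assay, at which 1 of the 3 values shown sits).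

Compound 4 `CCCC[S+]([O-])c1sc2nc(-c3nccs3)cc(-c3ccc(CN)cc3)c2c1N` has not yet been measured in this assay. It differs from compound 1 in one place: aminomethyl in place of dimethylcarbamoyl on an aromatic carbon. For the measured compounds named here, no pair of measured compounds in this set differs by such a change, so the size of the step is not known from the data. Compound 4 is expected to give 12 nM, with a likely range from 4 nM to 40 nM. The expected step is a 2.0-fold higher number from compound 1 to compound 4 (0.31 log units; beyond the scatter), a modest move toward weaker inhibition that sits near the edge of the scatter.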

Compound 4, half-maximal inhibitory concentration: 11.5 nM
Compound 4: middle estimate off by 1.0-fold (0.02 log units), on the high side, and the stated range covers the measured number.
By their numbers in this assay, from the lowest: compounds 1 and 4 (each within the scatter of the next); then compound 2.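

On a six-membered aromatic ring of carbon only, para to a large group, aminomethyl can stand in place of dimethylcarbamoyl with no difference that can be told from the scatter in this assay (a 1.9-fold higher number from compound 1 to compound 4 (0.29 log units; within the scatter)). For the compounds shown here, the earlier compounds offered no pair differing in this place, so this is the first reading of the position, and it shows that the smaller group, which brings a hydrogen-bond donor and has no carbonyl, leaves compound 1 and compound 4 indistinguishable. Nothing measured here gives a reason for this outcome.

On these data alone, it remains open how a carboxylic acid or a longer chain ending in an amine would read in this place. The compounds shown also leave open whether the same swap would read alike with other groups elsewhere on the shared core.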